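The compounds below may be only part of what the source reports. "The series", "measured", "known", "first", "only" and "open" are said of these compounds alone.

Measured in a functional assay on UACC-62 cells (Homo sapiens) for cytotoxicity, read by sulforhodamine B assay, with a stated time of 48 h; on this read-out higher numbers stand for lower toxicity in this test and lower numbers for higher toxicity in this test:
- compound 1 `ClCc1cccc(Cn2cnc3ncnc(Cl)c32)c1` gives 38900 nM
- compound 2 `ClCc1ccc(Cn2cnc3nc(Cl)nc(Cl)c32)cc1` gives 6020 nM
- compound 3 `ClCc1ccccc1Cn1cnc2ncnc(Cl)c21` gives 19100 nM

Compound 2 stands lowest of the three numbers in this assay; compound 3 is its nearest neighbour and compound 1 the furthest, and both gaps lie beyond the scatter. Compound 2 is the only one of the three that carries two chloro groups on the shared core.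

Compound 4 `ClCc1ccc(Cn2cnc3ncnc(Cl)c32)cc1` is not yet measured in this assay. It differs from compound 2 in one place: hydrogen in place of chloro on an aromatic carbon. Among the measured compounds shown here, no pair of measured compounds differs in only one place, so no measured step tells how much this exchange counts. What the numbers show is that compound 1 and compound 3, which each keep a single chloro on the core, sit well above compound 2.

Compound 4 is therefore expected to move upward from compound 2 by a step of about a 3.0-fold higher number from compound 2 to compound 4 (0.48 log units; beyond the scatter), beyond the scatter. The estimate for compound 4 in this assay is 18000 nM, with a range from 7000 nM to 45000 nM.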

Compound 4, concentration lethal to 50% of the cells: 34700 nM
For compound 4 the middle estimate is 1.9-fold (0.29 log units) below the measured one; low and high end bracket the measured number.
By their numbers in this assay, from the lowest: compound 2; then compounds 3, 4 and 1 (each within the scatter of the next, the first and the last beyond it).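

The exchange of chloro for hydrogen on the aromatic carbon between two ring nitrogen atoms now has a direct measure in this assay: a 5.8-fold higher number from compound 2 to compound 4 (0.76 log units; beyond the scatter). This chloro therefore counts on its own, with the rest of the structure unchanged, and its loss gives lower toxicity in this test. No measurement at hand offers an explanation for the size of this step.

Compound 1 and compound 3 have no partner carrying the second chloro on the shared core, so whether the step holds for them cannot be read. Also open, as far as these compounds go, is how an amine or a methoxy group on this same aromatic carbon would compare with chloro and hydrogen.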